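From pyridin-4-yl to 4-chlorophenyl on the shared core

The source may hold more compounds than are shown below. What is called first, only, known or untested is meant among the compounds shown, and "the series" means these compounds.

In a functional assay on MIA PaCa-2 cells (Homo sapiens) for antiproliferative activity, read by MTT assay, with a stated time of 24 h (on this read-out higher numbers stand for weaker inhibition and lower numbers for stronger inhibition), compound 1 `COc1ccc(-c2noc(-c3ccncc3)n2)cc1OC1CCCC1` gives 9330 nM, and compound 2 `COc1ccc(-c2noc(-c3ccc(F)cc3)n2)cc1OC1CCCC1` gives 6090 nM. These two sit together, with a 1.5-fold lower number from compound 1 to compound 2 (0.19 log units; within the scatter). Compound 3 `COc1ccc(-c2noc(-c3cccnc3)n2)cc1OC1CCCC1` gives > 1000000 nM, which is a limit of the assay.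

Compound 4 `COc1ccc(-c2noc(-c3ccc(Cl)cc3)n2)cc1OC1CCCC1` has not yet been measured. It differs from compound 1 in one place, 4-chlorophenyl in place of pyridin-4-yl on an aromatic carbon: 4-chlorophenyl in place of pyridin-4-yl, on an aromatic carbon of a five-membered aromatic ring with 2 nitrogen and 1 oxygen. The closest guide is the swap to 4-fluorophenyl in compound 2, which gave a 1.5-fold lower number from compound 1 to compound 2 (0.19 log units; within the scatter). The large steps, an at least 100-fold higher number from compound 1 to compound 3 (2.03 log units; beyond the scatter) and an at least 160-fold higher number from compound 2 to compound 3 (2.21 log units; beyond the scatter), both involve pyridin-3-yl, a group that compound 4 does not carry, so they bear on it only weakly. No step beyond the scatter is therefore expected in this assay, in either direction. The estimated step is a 1.6-fold lower number from compound 1 to compound 4 (0.19 log units; within the scatter). For compound 4 the expected value is 6000 nM, within an estimated range of 2500 nM to 15000 nM.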

Compound 4, half-maximal inhibitory concentration: 740 nM
The estimate for compound 4 lay 8.1-fold (0.91 log units) above the measured number; the whole stated range lies above it.
By their numbers in this assay, from the lowest: compound 4; then compounds 2 and 1 (each within the scatter of the next). At a limit, above all of these: compound 3.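

In this assay, the swap to 4-fluorophenyl in compound 2 stayed within the scatter and the swap to pyridin-3-yl in compound 3 only pushed the number up, but this position can also bring a large fall: 4-chlorophenyl gives a 13-fold lower number from compound 1 to compound 4 (1.10 log units; beyond the scatter). The atom on the phenyl ring matters as well, since chloro in place of fluoro gives an 8.2-fold lower number from compound 2 to compound 4 (0.92 log units; beyond the scatter), so these two halogens are not interchangeable here. The widest gap, an at least 1300-fold lower number from compound 3 to compound 4 (3.13 log units; beyond the scatter), rests on a limit rather than a number: the limit of > 1000000 nM in this assay, at which 1 of the 4 values shown sits.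

The compounds shown leave open whether bromo or methyl in place of the chloro would lower the number further or lose the gain. They also cannot tell what lies behind the step from fluoro to chloro.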